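The source may report more compounds than this note shows. Statements on the series, on what has been measured and on what is new or still open speak of the compounds shown alone.

Measured so far in a functional assay on MDA-MB-435S cells (Homo sapiens) for antiproliferative activity, read by MTT assay, with a stated time of 72 h; a lower number here means a stronger inhibitor, a higher number a weaker inhibitor:
- compound 1 `O=c1c(CSC(=S)N2CCOCC2)coc2cc(Cl)ccc12`: 600 nM
- compound 2 `O=c1c(CSC(=S)N2CCCCC2)coc2cc(Cl)ccc12`: 240 nM
- compound 3 `O=c1c(CSC(=S)N2CCCC2)coc2cc(Cl)ccc12`: 6400 nM

Compound 3 gives the highest number of the three and is therefore the weakest inhibitor here. Its two neighbours differ only at the thiocarbonyl carbon: an 11-fold higher number from compound 1 to compound 3 (1.03 log units; beyond the scatter), and a 27-fold higher number from compound 2 to compound 3 (1.43 log units; beyond the scatter), while a 2.5-fold lower number from compound 1 to compound 2 (0.40 log units; beyond the scatter). Compound 4 `CC(C)N(C(=S)SCc1coc2cc(Cl)ccc2c1=O)C(C)C` is not yet measured; it differs from compound 3 by diisopropylamino in place of pyrrolidin-1-yl on a thiocarbonyl carbon. The earlier steps show that the five-membered ring is clearly unfavourable, so leaving it is expected to lower the number in this assay, though an open-chain amine has no direct precedent among these compounds. The estimated step is a 4.3-fold lower number from compound 3 to compound 4 (0.63 log units; beyond the scatter). Compound 4 is expected to give about 1500 nM, between 300 nM and 8000 nM.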

Compound 4, half-maximal inhibitory concentration: > 25000 nM
Compound 4: only a limit was reported; the forecaster's own chance of this, stated with the estimate: 5%; middle value at least 16-fold (1.22 log units) away from the limit.
By their numbers in this assay, from the lowest: compound 2; then compound 1; then compound 3. At a limit, above all of these: compound 4.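

Compound 4 gives only a limit in this assay, not a number: the limit of > 25000 nM in this assay, at which 1 of the 4 values shown sits. Leaving the five-membered ring therefore does not by itself lower the number, and diisopropylamino ranks behind all three rings, with an at least 3.9-fold higher number from compound 3 to compound 4 (0.59 log units; beyond the scatter), an at least 100-fold higher number from compound 2 to compound 4 (2.01 log units; beyond the scatter) and an at least 41-fold higher number from compound 1 to compound 4 (1.61 log units; beyond the scatter). On this thiocarbonyl carbon, then, the amine matters strongly, and the one open-chain amine shown sits at the weak end of the series.

Still open, as far as these compounds go, is how smaller open-chain amines such as dimethylamino or diethylamino would behave. Larger ring amines such as azepan-1-yl also remain open.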